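Piperazinyl Amide Follows a Pyrrolidinyl Amide in Paw Edema

This account rests on a few compounds, and the source may have more. Where it says the series, first, only, none or still open, it means among the compounds named here.

Compound 1, `COc1cc2c(cc1OC)C(CC(=O)NC(C)C)CC2`, gives 31.3% in a functional assay on the whole organism (strain Wistar) for inhibition, with Rattus norvegicus as the target, read by paw edema, with stated times of 60 min and 1 h, at a dose of 100 mg/kg by the oral route; on this read-out lower numbers stand for less inhibition and higher numbers for more inhibition at the one dose given (going by the name of the read-out).
Compound 2, `COc1cc2c(cc1OC)C(CC(=O)NC1CCCC1)CC2`, gives 40.6% in this assay.
Compound 3, `COc1cc2c(cc1OC)C(CC(=O)N1CCCC1)CC2`, gives 4.69% in this assay.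

Compound 3 stands lowest of the three numbers: it sits a number 26.6 percentage points lower from compound 1 to compound 3 (beyond the scatter) and a number 35.9 percentage points lower from compound 2 to compound 3 (beyond the scatter), both steps beyond the scatter. Compound 1 and compound 2 differ from each other by a number 9.3 percentage points higher from compound 1 to compound 2 (within the scatter), which stays within the scatter, so those two are not ordered.

Compound 4, `COc1cc2c(cc1OC)C(CC(=O)N1CCNCC1)CC2`, has not yet been measured in this assay. It differs from compound 3 in one place:

piperazin-1-yl in place of pyrrolidin-1-yl on a carbonyl carbon

The two steps that lead into compound 3 both exchange an amide bearing a hydrogen for a pyrrolidin-1-yl amide and both fall sharply. Within the data shown here, no measured step exchanges one ring on the amide nitrogen for another, so the move to piperazin-1-yl has no direct precedent here. The nearest guide is that the rise into compound 3 was lost rather than gained on the amide nitrogen, which argues for a small step, if any.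

Compound 4 is therefore expected to give about 12% in this assay, somewhere between 0% and 32%. The expected step is a number 7.3 percentage points higher from compound 3 to compound 4 (within the scatter), most likely within the scatter.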

Compound 4, a percentage reported as inhibition, in the whole organism at one dose (the size of the read-out at that dose, not a potency): 62.5%
Estimate against measurement, compound 4: 50.5 percentage points below; the whole stated range lies below it.
By their numbers in this assay, from the lowest: compound 3; then compounds 1 and 2 (each within the scatter of the next); then compound 4.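

At this place, on a carbonyl carbon whose other neighbour is a saturated chain carbon, a ring on the amide nitrogen does not by itself bring a low number in this assay: exchanging pyrrolidin-1-yl for piperazin-1-yl gives a number 57.8 percentage points higher from compound 3 to compound 4 (beyond the scatter). Nor does the read-out depend on keeping the amide hydrogen, since compound 4 lacks it and still exceeds both open-chain and cycloalkyl amides, with a number 31.2 percentage points higher from compound 1 to compound 4 (beyond the scatter) and a number 21.9 percentage points higher from compound 2 to compound 4 (beyond the scatter). The entering piperazin-1-yl is a six-membered non-aromatic ring with 2 hetero atoms and 1 hydrogen-bond donor, whereas the leaving pyrrolidin-1-yl is a five-membered non-aromatic ring with 1 hetero atom and 0 hydrogen-bond donors, and nothing in the data shown accounts for the rise.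

The compounds shown leave open whether the larger ring or the second ring nitrogen goes with the higher number, a question that piperidin-1-yl and morpholin-4-yl at the same carbonyl carbon would separate. They also leave open how the number responds to a methyl or acetyl group on the free ring nitrogen of piperazin-1-yl.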